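Replacing 4-bromophenyl in compound 1 with 6-phenylpyridin-3-yl

This account rests on a few compounds, and the source may have more. Where it says the series, first, only, none or still open, it means among the compounds named here.

In a functional assay on MCF7 cells (Homo sapiens) for inhibition, with a stated time of 72 h (a higher number here means a weaker inhibitor, a lower number a stronger inhibitor), compound 1 `NC1CCC(Nc2nc(NCc3ccc(Br)cc3)c3ncn(C4CCCC4)c3n2)CC1` gives 850 nM, the middle number of three. Compound 2 `NC1CCC(Nc2nc(NCc3ccc(-c4cccc(F)c4)cc3)c3ncn(C4CCCC4)c3n2)CC1` gives 293 nM, and compound 3 `CC(C)(O)CNc1nc(NCc2ccc(-c3ccco3)cc2)c2ncn(C3CCCC3)c2n1` gives 15300 nM.

Compound 4 `NC1CCC(Nc2nc(NCc3ccc(-c4ccccc4)nc3)c3ncn(C4CCCC4)c3n2)CC1` departs from compound 1 on a saturated chain carbon bound to a nitrogen on an aromatic ring: 6-phenylpyridin-3-yl in place of 4-bromophenyl on a saturated chain carbon bound to a nitrogen on an aromatic ring.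

Within the data shown here, the one measured step that bears on this change is a 2.9-fold lower number from compound 1 to compound 2 (0.46 log units; beyond the scatter), where 3-fluorophenyl replaces bromo. Among the measured compounds shown here, no measured compound tests the aromatic ring with a hetero atom, so the read-across is loose. A modest move to a lower number in this assay is expected, of similar size to that step. The expected step is a 2.8-fold lower number from compound 1 to compound 4 (0.45 log units; beyond the scatter).

Compound 4 is estimated at 300 nM, within a range of 90 nM to 1000 nM.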

Compound 4, half-maximal inhibitory concentration: 483 nM
For compound 4 the middle estimate is 1.6-fold (0.21 log units) below the measured one, within the range that was stated.
By their numbers in this assay, from the lowest: compounds 2, 4 and 1 (each within the scatter of the next, the first and the last beyond it); then compound 3.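

In this assay the change to 6-phenylpyridin-3-yl gives a 1.8-fold lower number from compound 1 to compound 4 (0.25 log units; within the scatter) and so no separable shift in this number. On a saturated chain carbon bound to a nitrogen on an aromatic ring, the two-ring group with 12 heavy atoms therefore holds the level of 4-bromophenyl, unlike the step of a 2.9-fold lower number from compound 1 to compound 2 (0.46 log units; beyond the scatter) for the other two-ring change. No measurement shown explains this result.

Biphenyl-4-yl, with carbon-only rings, would be needed in this place to separate the ring nitrogen from the added ring. As far as these compounds go, the effect of an amine or a carboxylic acid on that added ring remains open.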